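Restoring an Aromatic Arm on the Amide Nitrogen

The source may hold more compounds than are shown below. What is called first, only, known or untested is meant among the compounds shown, and "the series" means these compounds.

Compound 2 `COC(=O)/C=C/c1cccc(N(C)C(=O)C2CCCCC2)c1` carries only a methyl on the amide nitrogen. In an assay on isolated protein with Bile acid receptor (Homo sapiens) as the target (on this read-out higher numbers stand for an effect only at larger amounts of compound and lower numbers for an effect already at smaller amounts), compound 2 reaches only > 1000 nM, which is a limit of the assay rather than a number, so it sits at the limit of > 1000 nM in this assay, at which 1 of the 2 values shown sits. Compound 1 `COC(=O)/C=C/c1cccc(N(Cc2ccc(/C=C/c3ccccc3F)cc2)C(=O)C2CCCCC2)c1`, which bears a much larger substituted benzyl arm on the same nitrogen, gives 64 nM in this assay. Compound 3 `COC(=O)/C=C/c1cccc(N(Cc2cc(OC)cc(OC)c2)C(=O)C2CCCCC2)c1` has not been measured; it differs from compound 2 by 3,5-dimethoxyphenyl in place of hydrogen on a saturated chain carbon bound to an amide-type nitrogen. This change reinstates an aromatic group on the chain carbon bound to the amide nitrogen, a feature that compound 2 lacks and compound 1 carries. The step of an at least 3.3-fold lower number from compound 2 to compound 3 (0.52 log units; beyond the scatter) is expected to point toward an effect at smaller amounts, beyond the usual scatter. The estimate for compound 3 is 300 nM in this assay. The expected range for compound 3 runs from 60 nM to 1500 nM.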

Compound 3, half-maximal effective concentration: 606 nM
The estimate for compound 3 lay 2.0-fold (0.31 log units) below the measured number; the measured number falls inside the stated range.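

In this assay the 3,5-dimethoxyphenyl group on the saturated chain carbon bound to an amide-type nitrogen gives compound 3 a value that can be read as a number, which the methyl-bearing compound 2 does not offer. Compound 2 stands only at a limit of the assay: the limit of > 1000 nM in this assay, at which 1 of the 3 values shown sits. The change therefore reads as an at least 1.6-fold lower number from compound 2 to compound 3 (0.21 log units; that floor lies within the scatter), so the true size of the step may be larger, but this pair does not establish it as beyond the scatter.

Compound 3 gives 606 nM, whereas compound 1 gives 64 nM, and the compounds shown do not tell which features of the larger arm go with the lower number. Also open, from the compounds shown here alone, is how an unsubstituted phenyl, a pyridine ring or a carboxylic acid on the same chain carbon would read in this assay.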